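A few compounds are considered here, and "the series" means these few. Any claim that something is new, unique, unknown or untested is made for them only; others in the source may bear on it.

Of the compounds shown here, three built on one shared core have been measured in an assay on HEK293 cells for displacement of a labelled ligand from 5-hydroxytryptamine receptor 7 (Rattus norvegicus), with a stated time of 60 min; a higher number here means a weaker inhibitor, a lower number a stronger inhibitor. Compound 2 `Clc1ccc(-c2cn(Cc3ccccc3)c3c2CNCC3)c(Cl)c1` gives 2070 nM, the lowest of the three numbers. Compound 1 `FC(F)(F)Oc1ccc(-c2cn(Cc3ccccc3)c3c2CNCC3)cc1` gives 10000 nM, and compound 3 `Clc1cccc(-c2cn(Cc3ccccc3)c3c2CNCC3)c1` gives 10000 nM. For the measured compounds named here, the only single change among them is the one from compound 2 to compound 3, where the 2,4-dichlorophenyl becomes a 3-chlorophenyl; that step is a 4.8-fold higher number from compound 2 to compound 3 (0.68 log units; beyond the scatter), so taking away chlorine from this ring made the binding clearly weaker. Compound 1, which carries a trifluoromethoxy group on the same ring, also sits at the high end.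

Compound 4 `COc1ccc(-c2cn(Cc3ccccc3)c3c2CNCC3)cc1` differs from compound 2 in one place: 4-methoxyphenyl in place of 2,4-dichlorophenyl on an aromatic carbon. Going by the values given here, the one measured step that bears on this, from compound 2 to compound 3, removed chlorine and gave a modest loss; compound 1 shows that an oxygen-linked group on this ring also goes with a weak number. Among the compounds with values here, no compound yet shows a methoxy group here. The expected outcome is therefore a loss of similar size, with compound 4 estimated at 8000 nM in this assay, within a range of 3000 nM to 15000 nM. This estimate means an expected step of a 3.9-fold higher number from compound 2 to compound 4 (0.59 log units; beyond the scatter).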

Compound 4, inhibition constant: 290 nM
Compound 4: the middle estimate sits 28-fold (1.44 log units) above what was measured; measured number below the stated range.
By their numbers in this assay, from the lowest: compound 4; then compound 2; then compounds 1 and 3 (each within the scatter of the next).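

In this assay, for the compounds shown here, the earlier compounds showed only losses at this position, but the step from 2,4-dichlorophenyl to 4-methoxyphenyl is a gain, with a 7.1-fold lower number from compound 2 to compound 4 (0.85 log units; beyond the scatter), so a ring without chlorine can bind better than one with two chlorines. The ring in compound 4 also far outperforms the 3-chlorophenyl ring, with a 34-fold lower number from compound 3 to compound 4 (1.54 log units; beyond the scatter), which shows that the group on this aromatic carbon can change the number by a large amount. The most telling comparison changes only what sits on the oxygen: methyl in place of trifluoromethyl gives a 34-fold lower number from compound 1 to compound 4 (1.54 log units; beyond the scatter), so an oxygen-linked group on this ring does not by itself go with a weak number, as compound 1 alone had suggested.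

No measurement at hand explains why these groups differ so much. Also open, from the compounds shown here alone, is how much of the gain depends on the methyl itself and on its place on the ring, which 4-ethoxyphenyl, 4-hydroxyphenyl or 3-methoxyphenyl at the same position could help to separate.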